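Shortening the butyl chain: what compound 3 might give

The source may hold more compounds than are shown below. What is called first, only, known or untested is meant among the compounds shown, and "the series" means these compounds.

Compound 1, `CCc1cncc(OC[C@@H]2CCCN2C)c1`, gives 1000 nM in an assay on K177 cells for activation of Neuronal acetylcholine receptor; alpha4/beta2 (Homo sapiens); on this read-out lower numbers stand for an effect already at smaller amounts and higher numbers for an effect only at larger amounts of compound.
Compound 2, `CCCCc1cncc(OC[C@@H]2CCCN2C)c1`, gives only a limit of the assay, > 1000000 nM, in this assay.

Compound 2 thus sits at the assay limit (the limit of > 1000000 nM in this assay, at which 1 of the 2 values shown sits), the weaker end of the two numbers shown. Compound 3, `CCCc1cncc(OC[C@@H]2CCCN2C)c1`, differs from it by hydrogen in place of methyl on a saturated chain carbon, three bonds along the chain from an aromatic carbon. Within the data shown here, the only measured step bearing on this, an at least 1000-fold higher number from compound 1 to compound 2 (3.00 log units; beyond the scatter), went the other way along the same chain. Trimming the chain back part way is therefore expected to recover some of that loss, giving a step of about an at least 20-fold lower number from compound 2 to compound 3 (1.30 log units; beyond the scatter) toward smaller amounts. Compound 3 is estimated at 50000 nM, within a range of 5000 nM to 1000000 nM.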

Compound 3, half-maximal effective concentration: > 1000000 nM
Compound 3: only a limit was reported; the forecaster's own chance of this, stated with the estimate: 35%; at least 20-fold (1.30 log units) between middle value and limit.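

Lengthening the ethyl of compound 1 by a single methyl is already enough for the large loss (an at least 1000-fold higher number from compound 1 to compound 3 (3.00 log units; beyond the scatter)), so that loss does not depend on reaching the butyl chain. Compound 3 gives a limit of the assay, > 1000000 nM, just as compound 2 does, so the step between the propyl and butyl chains cannot be read. Two of the values now sit at the same ceiling: the limit of > 1000000 nM in this assay, at which 2 of the 3 values shown sit.

Still open, going by these compounds, is whether a shorter group than ethyl, such as methyl, gives a lower number than compound 1. Also open, on these data alone, is whether an amine at the end of a propyl chain would bring the effect back.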